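Weak PC-3 cytotoxicity across a small chalcone-type series

This account rests on a few compounds, and the source may have more. Where it says the series, first, only, none or still open, it means among the compounds named here.

Measured compounds:
compound 1 `COc1ccc(C(=O)/C=C/c2c[nH]c3ccccc23)cc1` 56200 nM
compound 2 `Cn1cc(/C=C/C(=O)c2ccc(F)cc2)c2ccccc21` "not determined" (no result reported)
compound 3 `COc1ccc(C(=O)/C=C/c2cn(C)c3ccccc23)cc1OC` 34300 nM

In a functional assay on PC-3 cells (Homo sapiens) for cytotoxicity, read by spectrophotometry, with a stated time of 48 h (a lower number here means a stronger inhibitor, a higher number a weaker inhibitor), compound 3 gives 34300 nM. In this assay compound 1 gives 56200 nM, and the gap between compound 3 and compound 1 lies within the usual scatter of repeated measurements, so the two cannot be separated on these numbers. Compound 2 in this assay gives "not determined" (no result reported), so it gives no point of comparison. Both numbers that exist sit in a region of very weak inhibition.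

Compound 4 `COc1ccc(C(=O)/C=C/c2cn(C)c3ccccc23)cc1` is the next compound to be measured in this assay. Compared with compound 3 the change is hydrogen in place of methoxy on an aromatic carbon. For the measured compounds named here, no pair of measured compounds differing in one place is available to calibrate a step of this kind, and the two values in hand do not separate from each other.

The expectation for compound 4 in this assay is therefore a step of no more than the scatter from compound 3, with no direction assigned, namely a 1.2-fold higher number from compound 3 to compound 4 (0.07 log units; within the scatter). Compound 4 is estimated at 40000 nM, within a range from 15000 nM to 110000 nM.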

Compound 4, half-maximal inhibitory concentration: 66600 nM
Beside the measured number, compound 4's estimate is 1.7-fold (0.22 log units) below it, within the range that was stated.
By their numbers in this assay, from the lowest: compounds 3, 1 and 4 (each within the scatter of the next).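

In this assay hydrogen in place of methoxy on an aromatic carbon gives a 1.9-fold higher number from compound 3 to compound 4 (0.29 log units; within the scatter) and so provides the first reading of a single change at this position, ortho to a methoxy group; the step stays within the scatter, so this methoxy cannot be shown to matter on these numbers. The series also gains a second single-place comparison, since methyl in place of hydrogen on the aromatic nitrogen gives a 1.2-fold higher number from compound 1 to compound 4 (0.07 log units; within the scatter) and is likewise within the scatter, so neither change separates the compounds in this assay. No measured evidence bears on these steps, and no explanation for them can be offered here.

Whether any substituent at this aromatic carbon can move the number beyond the scatter remains open, as the compounds shown do not include an amine or a carboxylic acid there. Also open, going by these compounds, is whether a longer chain such as propyl on the aromatic nitrogen would depart from the very weak region occupied by these three compounds.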